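The compounds below may be only part of what the source reports. "The series", "measured", "known", "first", "only" and "open" are said of these compounds alone.

Working notes on the series. Compound 1 `C#Cc1cc(-c2nc3ccccc3s2)ccc1N` is the parent of this set. Within the data shown here, in a functional assay on MCF7 cells (Homo sapiens) for inhibition, with a stated time of 72 h (on this read-out higher numbers stand for weaker inhibition of growth and lower numbers for stronger inhibition of growth), compound 1 gives 49 nM, which is the second highest of the three numbers measured so far. The two measured neighbours both vary the shared core by a fluoro in place of hydrogen on an aromatic carbon: compound 2 `C#Cc1cc(-c2nc3c(F)cccc3s2)ccc1N` gives 110 nM in this assay, a step of a 2.2-fold higher number from compound 1 to compound 2 (0.35 log units; beyond the scatter), while compound 3 `C#Cc1cc(-c2nc3cc(F)ccc3s2)ccc1N` gives 11 nM, a step of a 4.5-fold lower number from compound 1 to compound 3 (0.65 log units; beyond the scatter). Both steps lie beyond the scatter but remain modest, and they pull in opposite directions.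

Compound 4 `C[Si](C)(C)C#Cc1cc(-c2nc3ccccc3s2)ccc1N` is not yet measured in this assay. It differs from compound 1 by a group of 4 heavy atoms (3 carbon, 1 silicon; no ring) in place of a hydrogen atom, on a triple-bonded carbon. Neither measured step touches this part of the structure; both alter the aromatic part of the core, so they give no direct read on a change at the triple-bonded carbon. The expectation for compound 4 therefore rests on little more than the modest size of the steps seen so far, and a step of a 3.1-fold higher number from compound 1 to compound 4 (0.49 log units; beyond the scatter) is estimated, with wide uncertainty in either direction. For compound 4 a value of 150 nM is expected, within a range from 30 nM to 1500 nM.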

Compound 4, concentration for 50% growth inhibition: 710 nM
Estimate against measurement, compound 4: 4.7-fold (0.68 log units) below; the measured number falls inside the stated range.
By their numbers in this assay, from the lowest: compound 3; then compound 1; then compound 2; then compound 4.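

The position on the triple-bonded carbon proves far from silent: in this assay, the group of 4 heavy atoms (3 carbon, 1 silicon; no ring) in place of a hydrogen atom gives a 14-fold higher number from compound 1 to compound 4 (1.16 log units; beyond the scatter) and counts as a large step, whereas both fluoro changes on the aromatic part of the core were modest. The read-out therefore responds to change outside the aromatic part as well, and this replacement moves it towards weaker inhibition of growth. The data at hand offer no explanation for the size of this step.

Only one replacement at this position is shown, so it stays open whether the rise in the number follows the silicon atom or the group as a whole; a tert-butyl group, with carbon in place of silicon, and a smaller methyl group on the same triple-bonded carbon would separate the two readings. Also open, from the compounds shown here alone, is whether the fluoro change that lowers the number in compound 3 would do the same when combined with the group carried by compound 4.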